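A Chlorinated Amino Group Replaces a Trifluoromethylphenyl Unit

This account rests on a few compounds, and the source may have more. Where it says the series, first, only, none or still open, it means among the compounds named here.

Compound 1, with the structure `COc1cc(-c2nn(-c3cccc(NC(=O)c4ccc(Cl)c(C(F)(F)F)c4)c3)cc2-c2ccncc2)ccc1Cl`, was tested in a functional assay on IGROV-1 cells (Homo sapiens) for inhibition, read by sulforhodamine B assay, with a stated time of 48 h; on this read-out lower numbers stand for stronger inhibition of growth and higher numbers for weaker inhibition of growth. In this assay compound 1 gives > 32500 nM, a value that is a limit of the assay and not a measured number. That places compound 1 at the limit of > 32500 nM in this assay, at which 1 of the 2 values shown sits. A second measured compound, compound 2, with the structure `O=C(Nc1cccc(-n2cc(-c3ccncc3)c(-c3ccc(Cl)c(O)c3)n2)c1)Nc1ccc(Cl)c(C(F)(F)F)c1`, gives 2220 nM in this assay; its structure differs from compound 1 in more than one place, so the two values are simply shown side by side.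

Compound 3, with the structure `COc1cc(-c2nn(-c3cccc(NC(=O)Nc4ccc(Cl)c(Cl)c4)c3)cc2-c2ccncc2)ccc1Cl`, has not yet been measured in this assay. It differs from compound 1 in a single place: (3,4-dichlorophenyl)amino in place of 4-chloro-3-(trifluoromethyl)phenyl on a carbonyl carbon. Compound 3 keeps the methoxy-bearing ring of compound 1 while taking on an amino-linked carbonyl arrangement that compound 2 also carries. Since compound 1 sits at the limit, the size of the step cannot be fixed from it alone; compound 3 is expected to give a number within the measurable range, so the step of an at least 3.2-fold lower number from compound 1 to compound 3 (0.51 log units; beyond the scatter) is estimated to run toward stronger inhibition of growth, though with wide uncertainty. Compound 3 is estimated at 10000 nM, with a range from 2500 nM to 35000 nM.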

Compound 3, concentration for total growth inhibition: 3480 nM
For compound 3 the middle estimate is 2.9-fold (0.46 log units) above the measured one; measured number inside the range.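

In this assay, putting (3,4-dichlorophenyl)amino in place of 4-chloro-3-(trifluoromethyl)phenyl on a carbonyl carbon gives an at least 9.3-fold lower number from compound 1 to compound 3 (0.97 log units; beyond the scatter). Within the data shown here, this is the first change that can be read at a single place, and it shows that what sits on this carbonyl carbon has a clear bearing on growth inhibition in these cells, with the rest of the structure, including the methoxy-bearing ring, left as it is. The value for compound 1 is a limit of the assay and not a number, so the step gives only a minimum size, and the true gap may be wider: the limit of > 32500 nM in this assay, at which 1 of the 3 values shown sits.

The change alters two things at once, adding an amino link with its hydrogen-bond donor and replacing the trifluoromethyl group with a chlorine, so the compounds shown cannot tell which of the two carries the step. As far as these compounds go, it also remains open how the value would respond to a methylene group in place of that amino link, or to a methyl group or a fluorine in place of the chlorines on the ring.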